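The compounds below may be only part of what the source reports. "The series", "measured", "known", "first", "only" and "open" are said of these compounds alone.

Measured compounds in a functional assay on cells for agonist activity at Glucose-dependent insulinotropic receptor (Homo sapiens), read by a luciferase reporter, with a stated time of 4 h; a higher number here means that more compound is needed for the effect, a lower number that less compound is needed:
- compound 1 `CS(=O)(=O)c1ccc2c(c1)CCN2c1ncnc2c(C3CCN(c4ncccn4)CC3)coc12`: compound 1 gives 512 nM
- compound 2 `CC(C)(C)OC(=O)N1CCC(c2csc3c(Nc4ccc(S(C)(=O)=O)cc4F)ncnc23)CC1`: compound 2 gives 79 nM
- compound 3 `CC(C)(C)OC(=O)N1CCC(c2coc3c(Nc4ccc(S(C)(=O)=O)cc4F)ncnc23)CC1`: compound 3 gives 129 nM

Compound 1 gives the highest number of the three in this assay; the gaps to compound 3 and to compound 2 are both beyond the scatter, so on these numbers compound 1 needs the most compound for the effect. Going by the values given here, compounds 2 and 3 differ from compound 1 at several places at once, so no single-point step between measured compounds is available.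

Compound 4 `CS(=O)(=O)c1ccc2c(c1)CCN2c1ncnc2c(C3CCN(c4ncc(O)cn4)CC3)coc12` is the next compound for this assay. It differs from compound 1 by one change: hydroxy in place of hydrogen on an aromatic carbon. The change sits on the pyrimidin-2-yl group, which becomes 5-hydroxypyrimidin-2-yl; the rest of the structure is unchanged.

Among the compounds with values here, nothing among the measured compounds speaks to this change, so the expectation rests on its small size. The step from compound 1 to compound 4 is expected to be a 1.2-fold lower number from compound 1 to compound 4 (0.09 log units; within the scatter), which is within the usual scatter. For compound 4 a value of 420 nM is expected, with the range 150 nM to 1200 nM.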

Compound 4, half-maximal effective concentration: 391 nM
Beside the measured number, compound 4's estimate is 1.1-fold (0.03 log units) above it; the range from low to high includes it.
By their numbers in this assay, from the lowest: compounds 2 and 3 (each within the scatter of the next); then compounds 4 and 1 (each within the scatter of the next).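

In this assay, going by these compounds alone, the exchange of pyrimidin-2-yl for 5-hydroxypyrimidin-2-yl gives a 1.3-fold lower number from compound 1 to compound 4 (0.12 log units; within the scatter), and this is the first single-point comparison. It shows that a hydroxy group can stand on this aromatic carbon, two atoms from the ring nitrogen and para to a large group, while compound 4 remains within the scatter of compound 1; compound 2 and compound 3 differ from compound 1 at several places at once and could not show this. No supporting measurement bears on the reason for this result.

Still open, from the compounds shown here alone, is whether this carbon accepts other groups, such as an amine, a methoxy group or a carboxylic acid, or whether any of them would move the number beyond the scatter in either direction. Also open, going by these compounds, is whether a hydroxy group would read the same on another carbon of that ring, as one substituted compound at one place describes neither a trend nor a limit for the position.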